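Oxan-4-yl in place of the oxadiazolyl group on the core

The compounds below may be only part of what the source reports. "The series", "measured", "known", "first", "only" and "open" are said of these compounds alone.

In an assay on CHO cells for displacement of a labelled ligand from Substance-P receptor (Homo sapiens) (a higher number here means a weaker inhibitor, a lower number a stronger inhibitor), compound 3 `CCc1noc(C2=CC(=O)N3C[C@H](O[C@H](C)c4cc(C(F)(F)F)cc(C(F)(F)F)c4)[C@@H](c4ccc(F)cc4)C3C2)n1` gives 0.4 nM, the lowest number among the three measured compounds; compound 1 `C[C@@H](O[C@H]1CN2C(=O)C=C(c3ccc(F)cc3)CC2[C@@H]1c1ccc(F)cc1)c1cc(C(F)(F)F)cc(C(F)(F)F)c1` gives 2 nM and compound 2 `C[C@@H](O[C@H]1CN2C(=O)C=C(c3ccc(NS(C)(=O)=O)cc3)CC2[C@@H]1c1ccc(F)cc1)c1cc(C(F)(F)F)cc(C(F)(F)F)c1` gives 1 nM. Compound 4 `C[C@@H](O[C@H]1CN2C(=O)C=C(C3CCOCC3)CC2[C@@H]1c1ccc(F)cc1)c1cc(C(F)(F)F)cc(C(F)(F)F)c1` carries oxan-4-yl in place of 3-ethyl-1,2,4-oxadiazol-5-yl on a double-bonded ring carbon. Among the measured compounds shown here, no measured step exchanges an aromatic substituent on the double-bonded ring carbon for a saturated ring. The steps that come closest are a 5.0-fold lower number from compound 1 to compound 3 (0.70 log units; beyond the scatter) and a 2.5-fold lower number from compound 2 to compound 3 (0.40 log units; beyond the scatter), both showing that the 3-ethyl-1,2,4-oxadiazol-5-yl group gives a lower number than either phenyl-bearing substituent. Without that group, compound 4 is expected to give a modestly higher number than compound 3, an estimated 5.0-fold higher number from compound 3 to compound 4 (0.70 log units; beyond the scatter). Compound 4 is therefore estimated at 2 nM, with a range from 0.5 nM to 8 nM.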

Compound 4, half-maximal inhibitory concentration: 0.09 nM
Beside the measured number, compound 4's estimate is 22-fold (1.35 log units) above it; measured number below the stated range.
By their numbers in this assay, from the lowest: compound 4; then compound 3; then compounds 2 and 1 (each within the scatter of the next).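

In this assay, the oxan-4-yl group on the double-bonded ring carbon gives a 4.4-fold lower number from compound 3 to compound 4 (0.65 log units; beyond the scatter) and so shows that this position needs no aromatic ring for a low number. The same exchange gives an 11-fold lower number from compound 2 to compound 4 (1.05 log units; beyond the scatter) and a 22-fold lower number from compound 1 to compound 4 (1.35 log units; beyond the scatter), which places the only saturated ring here ahead of all three aromatic substituents. Nothing measured explains this order. The compounds shown leave open whether the ring oxygen of oxan-4-yl matters, which a cyclohexyl ring or a piperidine, with its ring amine, would address.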